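The source may report more compounds than this note shows. Statements on the series, on what has been measured and on what is new or still open speak of the compounds shown alone.

In a functional assay on the whole organism with Scenedesmus acutus as the target, with a stated time of 20 h (on this read-out higher numbers stand for weaker inhibition and lower numbers for stronger inhibition), compound 1 `O=C1C2=C(CCCC2)C(=O)N1c1ccc(Cl)cc1F` gives 240 nM, compound 2 `COC(=O)c1cc(N2C(=O)C3=C(CCCC3)C2=O)c(F)cc1Cl` gives 170 nM, and compound 3 `CCCOC(=O)c1cc(N2C(=O)C3=C(CCCC3)C2=O)c(F)cc1Cl` gives 66.1 nM, the lowest of these three numbers. Compound 4 `CC(C)OC(=O)c1cc(N2C(=O)C3=C(CCCC3)C2=O)c(F)cc1Cl` has not yet been measured. It has the same atoms as compound 3, joined differently: isopropyl in place of propyl on an oxygen next to a carbonyl group, with isopropyl in place of propyl on an oxygen next to a carbonyl group. Among the measured compounds shown here, the steps that bear on this are small: a 2.6-fold lower number from compound 2 to compound 3 (0.41 log units; beyond the scatter) and a 3.6-fold lower number from compound 1 to compound 3 (0.56 log units; beyond the scatter) are modest, and a 1.4-fold lower number from compound 1 to compound 2 (0.15 log units; within the scatter) lies within the scatter. None of them swaps propyl for isopropyl, so no direction can be expected with confidence, and no change beyond the scatter is expected. The expected change is a 1.1-fold higher number from compound 3 to compound 4 (0.05 log units; within the scatter). The estimate for compound 4 is 75 nM, with an expected range of 32 nM to 175 nM.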

Compound 4, half-maximal inhibitory concentration: 89.1 nM
The estimate for compound 4 lay 1.2-fold (0.07 log units) below the measured number; the measured number falls inside the stated range.
By their numbers in this assay, from the lowest: compounds 3, 4, 2 and 1 (each within the scatter of the next, the first and the last beyond it).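

In this assay, swapping propyl for the branched isopropyl on this ester oxygen produces no change that can be told from the scatter (a 1.3-fold higher number from compound 3 to compound 4 (0.13 log units; within the scatter)), so branching at this point is tolerated. Isopropyl in place of methyl also stays within the scatter (a 1.9-fold lower number from compound 2 to compound 4 (0.28 log units; within the scatter)), while the whole isopropoxycarbonyl group in place of hydrogen on the aromatic carbon goes beyond it (a 2.7-fold lower number from compound 1 to compound 4 (0.43 log units; beyond the scatter)). Nothing measured here offers an explanation for these numbers. Still open, going by these compounds, is how a longer chain such as butyl, or a carboxylic acid in place of the ester, would read out.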